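The compounds below may be only part of what the source reports. "The series", "measured", "known", "first", "only" and "open" are said of these compounds alone.

Two thiosemicarbazone-type compounds built around a shared core have been measured in a functional assay on HeLa cells (Homo sapiens) for cytotoxicity, read by MTT assay, with a stated time of 72 h; a higher number here means a weaker inhibitor, a lower number a stronger inhibitor. Compound 1 `N/C(=N\NC(=S)N1CCN(c2ccccn2)CC1)c1ccc(F)cn1` gives 2000 nM in this assay. Compound 2 `Cc1cccc(/C(N)=N/NC(=S)N2CCSCC2)n1` gives 1800 nM in this assay. Among these two numbers that of compound 2 is the lower one, but the two values lie within the scatter of each other, so on the present data neither compound can be called the stronger inhibitor.

Compound 3 `Cc1cccc(/C(N)=N/NC(=S)N2CCCCC2)n1` has not yet been measured. It differs from compound 2 in a single place: piperidin-1-yl in place of thiomorpholin-4-yl on a thiocarbonyl carbon. Among the compounds with values here, no step of this kind between measured compounds is available here, so there is nothing in these data to show how such an exchange on the thiocarbonyl carbon affects this assay.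

Within the data shown here, with no measured step to lean on, the expectation for compound 3 is a step of a 1.1-fold higher number from compound 2 to compound 3 (0.05 log units; within the scatter) from compound 2, a change that is not expected to exceed the usual scatter in either direction. Compound 3 is therefore estimated to give 2000 nM in this assay, with a range from 800 nM to 5000 nM.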

Compound 3, half-maximal inhibitory concentration: 2000 nM
Estimate against measurement, compound 3: no gap at the digits printed; the measured number falls inside the stated range.
By their numbers in this assay, from the lowest: compounds 2, 1 and 3 (each within the scatter of the next).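

Within the data shown here, this is the first measured exchange at this place, the thiocarbonyl carbon, with the rest of the molecule left unchanged. Putting piperidin-1-yl in place of thiomorpholin-4-yl gives in this assay a 1.1-fold higher number from compound 2 to compound 3 (0.05 log units; within the scatter), so the two compounds cannot be told apart here, and the sulfur of the thiomorpholin-4-yl ring is not required to keep the number of compound 3 level with that of compound 2 in this assay. Among these compounds, nothing else is at hand that would explain this outcome, and a single pair shows only that these two rings read alike, not that this place tolerates every group.

From the compounds shown here alone, it remains open whether morpholin-4-yl, which carries an oxygen in its ring, or an open-chain dimethylamino group on the same thiocarbonyl carbon would also stay within the scatter of compound 2. Among the compounds shown here, it is equally open whether the same exchange of rings would read the same way on a different remainder of the molecule, such as the fluorinated part of compound 1, since only one such pair is available so far.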